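Extending and capping the piperazine in a CXCR4 antagonist series

This account rests on a few compounds, and the source may have more. Where it says the series, first, only, none or still open, it means among the compounds named here.

Compound 2 `c1ccc2c(c1)CN[C@@H](CN(CCN1CCNCC1)[C@H]1CCCc3cccnc31)C2` carries the higher of the two numbers seen so far: in a functional assay on CCRF-CEM cells for antagonist activity at C-X-C chemokine receptor type 4 (Homo sapiens), read by calcium flux, with stated times of 25 min and 90 s (on this read-out lower numbers stand for stronger inhibition and higher numbers for weaker inhibition), compound 2 gives 553 nM, while compound 1 `c1ccc2c(c1)CN[C@@H](CN(CCC1CCNCC1)[C@H]1CCCc3cccnc31)C2` gives 150 nM. Among the compounds with values here, the one measured step, a 3.7-fold higher number from compound 1 to compound 2 (0.57 log units; beyond the scatter), shows the shared core tolerating a change at this chain position only at a modest cost. Compound 3 `c1ccc2c(c1)CN[C@@H](CN(CCCN1CCN(C3CC3)CC1)[C@H]1CCCc3cccnc31)C2` differs from compound 2 by (4-cyclopropylpiperazin-1-yl)methyl in place of piperazin-1-yl on a saturated chain carbon, two bonds along the chain from an amine nitrogen. Within the data shown here, no measured step covers an added methylene or the cyclopropyl cap, so the expectation leans on compound 2 alone: compound 3 is estimated to give 400 nM (range 100 nM to 1600 nM), an expected step of a 1.4-fold lower number from compound 2 to compound 3 (0.14 log units; within the scatter), within the scatter.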

Compound 3, half-maximal inhibitory concentration: 50 nM
Beside the measured number, compound 3's estimate is 8.0-fold (0.90 log units) above it; measured number outside the range, below it.
By their numbers in this assay, from the lowest: compound 3; then compound 1; then compound 2.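

The step to (4-cyclopropylpiperazin-1-yl)methyl gives an 11-fold lower number from compound 2 to compound 3 (1.04 log units; beyond the scatter) in this assay and so this position can gain as well as lose, where the earlier step showed only a loss. Against piperidin-4-yl the same group gives a 3.0-fold lower number from compound 1 to compound 3 (0.48 log units; beyond the scatter) and so the gain goes beyond recovering what piperazin-1-yl gave up. No evidence at hand accounts for this gain. The change joins an added methylene to a cyclopropyl cap, and the compounds shown leave the share of each open. An uncapped piperazine on the longer chain, or a methyl or isopropyl cap, would separate the two.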